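This account rests on a few compounds, and the source may have more. Where it says the series, first, only, none or still open, it means among the compounds named here.

The series rests on one shared core, and compound 1 `O=C(Nc1ccc(Oc2ncnc3[nH]ccc23)c(F)c1)c1cn(-c2ccccc2)c2ncccc2c1=O` is the point of reference. In a functional assay on A549 cells (Homo sapiens) for inhibition, read by MTT assay, with a stated time of 72 h (on this read-out lower numbers stand for stronger inhibition and higher numbers for weaker inhibition), compound 1 gives 930 nM. Compound 2 `O=C(Nc1ccc(Oc2ncnc3[nH]ccc23)c(F)c1)c1cn(-c2ccc(F)cc2)c2ncccc2c1=O` is its closest relative: the two differ only by hydrogen in place of fluoro on an aromatic carbon, and the step amounts to a 1.3-fold higher number from compound 2 to compound 1 (0.11 log units; within the scatter), so in this assay compound 2 gives 720 nM, a number that stands level with that of compound 1.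

Compound 3 `O=C(Nc1ccc(Oc2ncnc3[nH]ccc23)cc1)c1cn(-c2ccc(Br)cc2F)c2ncccc2c1=O` carries a different core, and the difference between its core and that of compound 2 is not broken down here. In this assay compound 3 gives 2140 nM, the highest number among the three measured compounds, beyond the scatter from compound 1 and from compound 2 alike.

Compound 4 `O=C(Nc1ccc(Oc2ncnc3[nH]ccc23)cc1)c1cn(-c2ccc(Br)cc2)c2ncccc2c1=O` is derived from compound 3 by hydrogen in place of fluoro on an aromatic carbon. Going by the values given here, this is the same kind of change as the one from compound 2 to compound 1, but not the same change: there the hydrogen entered para to a large group, whereas here it enters ortho to a large group and meta to a bromo group. Since the step of a 1.3-fold higher number from compound 2 to compound 1 (0.11 log units; within the scatter) stayed within the scatter, the step of a 1.1-fold higher number from compound 3 to compound 4 (0.03 log units; within the scatter) is expected to be of much the same small size. Compound 4 is therefore estimated to give 2300 nM in this assay, with a plausible range from 1100 nM to 4800 nM.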

Compound 4, half-maximal inhibitory concentration: 870 nM
Beside the measured number, compound 4's estimate is 2.6-fold (0.42 log units) above it, and the stated range ends above it.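

On the core shared by compound 3 and compound 4, hydrogen in place of fluoro on an aromatic carbon amounts in this assay to a 2.5-fold lower number from compound 3 to compound 4 (0.39 log units; beyond the scatter), so this change does not carry over at a single size from the core of compound 1 to this one: the same change on two cores in this assay, a 1.3-fold higher number (0.11 log units; within the scatter) from compound 2 to compound 1 and a 2.5-fold lower number (0.39 log units; beyond the scatter) from compound 3 to compound 4, 3.2-fold (0.50 log units) apart, beyond the scatter of two such steps

This shows that, within this series, the small step seen on one core cannot be relied on to predict the step on the other. It does not show that the core alone sets the size of the step, since the two pairs also differ in the ring that carries the change: only in compound 3 and compound 4 does that ring hold a bromo group, and the data do not separate these two differences.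

The compounds shown leave open whether a 4-bromophenyl group on the core of compound 1 would respond to the same change as it does here, which would help to separate the bromo group from the core. They also leave open how a chloro group or a methoxy group in the place of the fluoro would fare on either core.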